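Hydroxymethyl to acetamidomethyl at the far end of a biphenyl

The source may hold more compounds than are shown below. What is called first, only, known or untested is meant among the compounds shown, and "the series" means these compounds.

Measured compounds:
compound 1 `O=C(O)CC/C=C\CO[C@H]1C(OCc2ccc(-c3ccc(CO)cc3)cc2)CC[C@@H]1N1CCCCCC1` — 3.16 nM
compound 2 `O=C(O)CC/C=C\CO[C@H]1C(OCc2ccc(-c3ccccc3)cc2)CC[C@@H]1N1CCCCC1` — 63.1 nM; 15.9 nM (2 entries)

In a functional assay on blood for antagonist activity at thromboxane A2 receptor (Homo sapiens) (a lower number here means tighter binding, a higher number weaker binding), compound 1 gives 3.16 nM. This is the only single number shown for it, and it sits lower than either entry of compound 2, which gives 63.1 nM; 15.9 nM (2 entries); the spread of those two entries the several entries of compound 2 in this assay, 63.1 nM; 15.9 nM (2 entries) shows how far repeated measurements of one compound can lie apart. Compound 1 and compound 2 differ in more than one place, so their values are reported side by side without a computed step.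

Compound 3 `CC(=O)NCc1ccc(-c2ccc(COC3CC[C@H](N4CCCCCC4)[C@H]3OC/C=C\CCC(=O)O)cc2)cc1` has not yet been measured. It differs from compound 1 in a single spot: acetamido in place of hydroxy on a saturated chain carbon bound to an aromatic carbon. The change touches the hydroxymethyl arm only, leaving the rest of the shared core untouched. Among the compounds with values here, with no measured step of this kind to lean on, the step from compound 1 to compound 3 is expected to be small, probably within the scatter, as a 1.4-fold higher number from compound 1 to compound 3 (0.15 log units; within the scatter). Compound 3 is therefore estimated at 4.5 nM, expected to fall between 1.5 nM and 14 nM.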

Compound 3, dissociation constant: 2.51 nM
For compound 3 the middle estimate is 1.8-fold (0.25 log units) above the measured one; the measured number falls inside the stated range.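

Within the data shown here, this is the first step in which only one place changes. On a saturated chain carbon bound to an aromatic carbon, acetamido with 4 heavy atoms replaces hydroxy with 1, and in this assay the result is a 1.3-fold lower number from compound 1 to compound 3 (0.10 log units; within the scatter). The far end of the biphenyl can therefore carry the longer acetamidomethyl arm with no readable change in the number, and both compounds keep one hydrogen-bond donor and one acceptor in the swapped group. A step this small cannot be separated from noise, as repeated entries for a single compound lie further apart than this: the several entries of compound 2 in this assay, 63.1 nM; 15.9 nM (2 entries)

From the compounds shown here alone, whether a primary amine or a carboxylic acid on the same chain carbon would also leave the number unchanged remains open. So does the question of how much longer the chain can grow, for example with a propionamido group in place of acetamido.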